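The compounds below may be only part of what the source reports. "The series", "measured", "known", "first", "only" and "open" are said of these compounds alone.

Compound 3 `COc1cc(Cl)cc(-c2nn(-c3cccc(NC(=O)Nc4ccc(Cl)c(Cl)c4)c3)cc2-c2ccncc2)c1` gives -10% in a functional assay on UO-31 cells (Homo sapiens) for inhibition, read by sulforhodamine B assay, with a stated time of 48 h, tested at 100 uM (a lower number here means a stronger effect, a higher number a weaker effect of the compound at the concentration tested), the highest number of the three measured. Compound 1 `O=C(Nc1cccc(-n2cc(-c3ccncc3)c(-c3cc(O)cc(Cl)c3)n2)c1)Nc1ccc(Cl)c(Cl)c1` gives -27%, and compound 2 `COc1cc(Cl)cc(-c2nn(-c3cccc(NC(=O)Nc4ccc(Cl)c(C(F)(F)F)c4)c3)cc2-c2ccncc2)c1` gives -50%. The step of a number 17 percentage points higher from compound 1 to compound 3 (beyond the scatter) was modest, while the step of a number 40 percentage points higher from compound 2 to compound 3 (beyond the scatter) was large. Compound 4 `COc1cc(Cl)cc(-c2nn(-c3cccc(NC(=O)c4cccc(C(F)(F)F)c4)c3)cc2-c2ccncc2)c1` differs from compound 3 in one place: 3-(trifluoromethyl)phenyl in place of (3,4-dichlorophenyl)amino on a carbonyl carbon. Within the data shown here, no measured step covers the loss of the amide-type nitrogen on the carbonyl carbon. Among the measured compounds shown here, the only bearing step is that from compound 2 to compound 3, where trifluoromethyl in place of chloro went with the lower number; the expected step of a number 18 percentage points lower from compound 3 to compound 4 (beyond the scatter) therefore points downward but with wide uncertainty. Compound 4 is estimated at -28%, within a range of -60% to 5%.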

Compound 4, a percentage reported as activity, at one concentration (the size of the read-out at that concentration, not a potency): 37%
Beside the measured number, compound 4's estimate is 65 percentage points below it; the measured number lies above the stated range.
By their numbers in this assay, from the lowest: compound 2; then compound 1; then compound 3; then compound 4.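

In this assay, replacing the arylamino group on the carbonyl carbon with 3-(trifluoromethyl)phenyl gave a number 47 percentage points higher from compound 3 to compound 4 (beyond the scatter) (large) and a number 87 percentage points higher from compound 2 to compound 4 (beyond the scatter) (large), and compound 4 alone among the four has a positive value, 37% (the others are negative). Trifluoromethyl therefore does not go with the lower number here, as it did on the ring of compound 2. Nothing measured here accounts for this shift.

The compounds leave open whether the lost nitrogen or the altered ring substitution carries the step. A methylene in place of that nitrogen, or a morpholine on the carbonyl carbon, also remains unaddressed by them.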